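A few compounds are considered here, and "the series" means these few. Any claim that something is new, unique, unknown or untested is made for them only; others in the source may bear on it.

Compound 2 `CC(C)C(O)(c1ccc(-c2ccc(Cl)cc2)cc1)c1c[nH]cn1` gives 28 nM in an assay on isolated protein for inhibition of steroid 17-alpha-hydroxylase/17,20 lyase (Homo sapiens) (a higher number here means a weaker inhibitor, a lower number a stronger inhibitor), the lowest of the three numbers measured; compound 1 `COc1ccc(-c2ccc(C(O)(c3c[nH]cn3)C(C)C)cc2)cc1` gives 54 nM and compound 3 `CC(=O)Nc1ccc(-c2ccc(C(O)(c3c[nH]cn3)C(C)C)cc2)cc1` gives 120 nM. The change to compound 4 `CC(C)C(O)(c1ccc(-c2ccccn2)cc1)c1c[nH]cn1` is pyridin-2-yl in place of 4-chlorophenyl on an aromatic carbon. Within the data shown here, no measured step swaps a whole ring; the known steps only exchange the group on that outer ring: a 1.9-fold lower number from compound 1 to compound 2 (0.29 log units; within the scatter), a 2.2-fold higher number from compound 1 to compound 3 (0.35 log units; beyond the scatter) and a 4.3-fold higher number from compound 2 to compound 3 (0.63 log units; beyond the scatter). These bear only loosely on the present change, so any expectation is uncertain; a modest weakening is estimated, as a 2.5-fold higher number from compound 2 to compound 4 (0.40 log units; beyond the scatter). Compound 4 is therefore expected to give about 70 nM in this assay, in the range 20 nM to 250 nM.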

Compound 4, half-maximal inhibitory concentration: 150 nM
The estimate for compound 4 lay 2.1-fold (0.33 log units) below the measured number, and the stated range covers the measured number.
By their numbers in this assay, from the lowest: compounds 2 and 1 (each within the scatter of the next); then compounds 3 and 4 (each within the scatter of the next).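

In this assay the exchange of the whole outer ring, rather than only the group on it, gives a 5.4-fold higher number from compound 2 to compound 4 (0.73 log units; beyond the scatter) and a 2.8-fold higher number from compound 1 to compound 4 (0.44 log units; beyond the scatter) at this position. So pyridin-2-yl, with its ring nitrogen and no outer substituent, ranks behind both substituted phenyl rings here. Nothing available explains this loss. On these data alone, what stays open is whether the ring nitrogen or the missing substituent matters more. A plain phenyl ring, or a pyridine ring carrying a chloro group, would help separate the two.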